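Ethoxy to methoxy on the aryl amine of compound 1

The compounds below may be only part of what the source reports. "The series", "measured", "known", "first", "only" and "open" are said of these compounds alone.

Compound 1 `CCOc1ccccc1NCn1nc(-c2ccc3c(c2)OCCO3)oc1=S` is measured in a functional assay, with a stated time of 6 min (on this read-out higher numbers stand for weaker inhibition and lower numbers for stronger inhibition), at 5280 nM. Compound 2 `S=c1oc(-c2ccc3c(c2)OCCO3)nn1CNc1cccc(Cl)c1` gives 6220 nM in this assay. The step of a 1.2-fold higher number from compound 1 to compound 2 (0.07 log units; within the scatter), 3-chlorophenyl in place of 2-ethoxyphenyl on the amine nitrogen, is within the scatter. Compound 1 thus has the lowest of the two numbers, though the gap to compound 2 is within the scatter.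

Compound 3 `COc1ccccc1NCn1nc(-c2ccc3c(c2)OCCO3)oc1=S` differs from compound 1 as follows: hydrogen in place of methyl on a saturated chain carbon bound to an oxygen on an aromatic ring. Within the data shown here, the only step measured so far, a 1.2-fold higher number from compound 1 to compound 2 (0.07 log units; within the scatter), exchanges the whole aryl group on the amine nitrogen and stays within the scatter, so trimming ethoxy to methoxy on that same 2-ethoxyphenyl is not expected to move this assay beyond the scatter in either direction. Compound 3 is therefore estimated at 5500 nM, between 2500 nM and 12000 nM, with the expected step of a 1.0-fold higher number from compound 1 to compound 3 (0.02 log units; within the scatter).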

Compound 3, half-maximal inhibitory concentration: 6300 nM
Compound 3: the middle estimate sits 1.1-fold (0.06 log units) below what was measured; the range from low to high includes it.
By their numbers in this assay, from the lowest: compounds 1, 2 and 3 (each within the scatter of the next).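

In this assay, trimming ethoxy to methoxy gives a 1.2-fold higher number from compound 1 to compound 3 (0.08 log units; within the scatter) and so adds a change within the 2-ethoxyphenyl group itself: loss of the methyl on the saturated chain carbon bound to an oxygen on an aromatic ring leaves no readable step. The exchange of 3-chlorophenyl for 2-methoxyphenyl gives a 1.0-fold higher number from compound 2 to compound 3 (0.01 log units; within the scatter) and is also unreadable, so compounds 1, 2 and 3 now all lie within the scatter of one another. No evidence is available to explain this flat read-out.

The compounds shown leave open whether any group on this aryl amine can move the number beyond the scatter. From the compounds shown here alone, what a longer chain such as butoxy, or a carboxylic acid on the phenyl ring, would do remains open, as does any change to the shared core.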